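A few compounds are considered here, and "the series" means these few. Any claim that something is new, unique, unknown or untested is made for them only; others in the source may bear on it.

Compound 1 `CSc1ccc(CNc2nc(SC)nc3ncccc23)cc1` gives the only numerical result in a functional assay on CCRF-CEM cells (Homo sapiens) for cytotoxicity, read by MTT assay, with a stated time of 72 h (a lower number here means that less compound is tolerated, a higher number that more compound is tolerated), among the two measured compounds, where compound 1 gives 59000 nM. Compound 2 `COc1ccc(CNc2nc(SC)nc3ccccc23)cc1` differs from it both in the core and in the group on the benzyl ring, and in this assay compound 2 reaches only a limit of the assay, > 100000 nM. One of the two values therefore sits at the limit of > 100000 nM in this assay, at which 1 of the 2 values shown sits. Compound 3 `CSc1nc(NCc2ccccc2)c2cccnc2n1` keeps the core of compound 1 and changes only the benzyl ring: hydrogen in place of methylsulfanyl on an aromatic carbon. Among the measured compounds shown here, no step between two measured compounds connects this change to a number, and the single other measured benzyl variant yields only a limit. The change is expected to move this assay little, within the scatter or toward a higher, better-tolerated value. For compound 3 the expected value in this assay is 80000 nM, with a range from 30000 nM to 200000 nM. This estimate corresponds to an expected step of a 1.4-fold higher number from compound 1 to compound 3 (0.13 log units; within the scatter).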

Compound 3, concentration lethal to 50% of the cells: > 100000 nM
Compound 3: no number, only a limit (the forecaster's own chance of this, stated with the estimate: 40%); middle value at least 1.2-fold (0.09 log units) away from the limit.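

Among the compounds shown here, with the core of compound 1 held fixed, this is the first change para to a large group on the benzyl ring that can be read as a step: hydrogen in place of methylsulfanyl gives an at least 1.6-fold higher number from compound 1 to compound 3 (0.22 log units; that floor lies within the scatter) in this assay. On these data alone, compound 3 reaches only a limit of the assay, so the step is a floor and its true size stays unknown. Compound 1, the only compound shown with methylsulfanyl on the benzyl ring, remains the only one with a number, and the other two share one limit: the limit of > 100000 nM in this assay, at which 2 of the 3 values shown sit.

The compounds shown leave open how far beyond the limit compound 3 lies. They also leave open whether an amine, a carboxylic acid or a longer chain at this place on the benzyl ring would give a number in this assay.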